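Adding 4-methoxyphenyl to the ring nitrogen of compound 1

This account rests on a few compounds, and the source may have more. Where it says the series, first, only, none or still open, it means among the compounds named here.

Values measured in a functional assay on MCF7 cells (Homo sapiens) for antiproliferative activity, read by MTT assay, with a stated time of 72 h (a higher number here means a weaker inhibitor, a lower number a stronger inhibitor), are as follows
- Compound 1 `O=C1COc2ccc(-c3cccc(NS(=O)(=O)c4ccc(F)cc4)c3)cc2N1` gives 18300 nM as a number
- Compound 2 `COc1cccc(N2C(=O)COc3ccc(-c4ccc(O)cc4)cc32)c1` gives > 40000 nM as a limit, not a number
- Compound 3 `O=C1COc2ccc(-c3cnc(Cl)c(NS(=O)(=O)c4ccc(F)cc4)c3)cc2N1c1ccccc1` gives > 40000 nM as a limit, not a number

Within the data shown here, compound 1 is the only one of the three with a true number (18300 nM) in this assay and so is the sole fixed point for comparison. Compound 4 `COc1ccc(N2C(=O)COc3ccc(-c4cccc(NS(=O)(=O)c5ccc(F)cc5)c4)cc32)cc1` keeps the core of compound 1 and makes one change, 4-methoxyphenyl in place of hydrogen on an amide-type nitrogen in a ring. Among the measured compounds shown here, no measured pair isolates this change. Compound 2 and compound 3 also carry an aromatic ring on that nitrogen, and both rest on the limit of > 40000 nM in this assay, at which 2 of the 3 values shown sit, in a sentence of their own standing, though they differ from compound 1 elsewhere too. A small move towards weaker inhibition in this assay is therefore expected, possibly none beyond the scatter. The estimated change is a 1.4-fold higher number from compound 1 to compound 4 (0.14 log units; within the scatter) in this reading. For compound 4 the expected value is 25000 nM with an estimated range from 9000 nM to 40000 nM in this assay's terms.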

Compound 4, half-maximal inhibitory concentration: 32400 nM
For compound 4 the middle estimate is 1.3-fold (0.11 log units) below the measured one; measured number inside the range.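

In this assay, among these compounds, the one readable step at this position is a 1.8-fold higher number from compound 1 to compound 4 (0.25 log units; within the scatter), and it lies within the usual scatter. Placing 4-methoxyphenyl on the amide-type nitrogen in a ring therefore leaves no change that can be told apart from repeat measurements in this pair. Compound 4 also shows that an aromatic ring at this place can still return a true number in this assay, which compound 2 and compound 3 could not show, since neither gives a number and any steps involving them cannot be read: the limit of > 40000 nM in this assay, at which 2 of the 4 values shown sit.

Going by these compounds, whether a methyl group or a longer chain ending in an amine on this nitrogen would read any differently remains open. So does whether a carboxylic acid on the added phenyl ring would shift the result.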